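Cytotoxicity notes on the series, compounds 1 to 3

The source may hold more compounds than are shown below. What is called first, only, known or untested is meant among the compounds shown, and "the series" means these compounds.

Compound 1 has the structure `COc1ccc(S(=O)(=O)N(CC(N)=O)c2ccc(N(CC(N)=O)S(=O)(=O)c3ccc(NC(C)=O)cc3)c3ccccc23)cc1`. In a functional assay on cells (Peritoneal macrophage, Mus musculus) for cytotoxicity, with a stated time of 24 h (a higher number here means that more compound is tolerated, a lower number that less compound is tolerated), compound 1 reaches only a limit of the assay, > 50000 nM. Compound 2, `CCN1CCN(CC(=O)Nc2ccc(S(=O)(=O)N(CC(N)=O)c3ccc(N(CC(N)=O)S(=O)(=O)c4ccc(OC)cc4)c4ccccc34)cc2)CC1`, carries 4-ethylpiperazin-1-yl where compound 1 has hydrogen on a saturated chain carbon bound to a carbonyl carbon. In this assay compound 2 likewise reaches only a limit of the assay, > 100000 nM. The step that the two limits leave unreadable from compound 1 to compound 2 therefore gives neither size nor direction, since the two values sit at the limit of > 100000 nM in this assay, at which 1 of the 2 values shown sits, and at the limit of > 50000 nM in this assay, at which 1 of the 2 values shown sits. Compound 2 thus stands at the limit of the assay, with no numerical value to compare against.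

Compound 3, `COc1ccc(S(=O)(=O)N(CC(N)=O)c2ccc(N(CC(N)=O)S(=O)(=O)c3ccc(NC(=O)CCN4CCCCC4)cc3)c3ccccc23)cc1`, differs from compound 2 by (piperidin-1-yl)methyl in place of 4-ethylpiperazin-1-yl on a saturated chain carbon bound to a carbonyl carbon. For the measured compounds named here, the only measured step that bears on this change is the unreadable one between compound 1 and compound 2, and it gives no size. No step beyond the scatter is therefore expected in this assay for this change, and compound 3 is expected to sit at a limit once more. The estimate for compound 3 in this assay is 100000 nM, within 40000 nM to 200000 nM. The step of a number no higher from compound 2 to compound 3 (the limit leaves the size open) is an expectation only.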

Compound 3, half-maximal cytotoxic concentration: > 100000 nM
Compound 3 was reported as a limit; the forecaster's own chance of this, stated with the estimate: 75%; the middle value lies on the limit itself.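

In this assay compound 3 gives only a limit of the assay, > 100000 nM. For the compounds shown here, compound 1, compound 2 and compound 3 all stand at limits, so no step among them can be read. The compounds shown leave open at what concentration any of the three becomes cytotoxic, and whether their side chains differ at all in this assay.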